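Notes on amide nitrogen substituents in this series

The source may report more compounds than this note shows. Statements on the series, on what has been measured and on what is new or still open speak of the compounds shown alone.

Among the measured compounds shown here, compound 3 `CCCCNC(=O)/C=C/c1c(/C=C/c2ccc(OC)cc2)cc(OC)cc1OC` gives 2080 nM in a functional assay on B16-F10 cells (Mus musculus) for inhibition, read by MTT assay, with a stated time of 48 h (a lower number here means a stronger inhibitor, a higher number a weaker inhibitor), the lowest of the three numbers so far. Compound 1 `COc1ccc(/C=C/c2cc(OC)cc(OC)c2/C=C/C(=O)N2CCN(C)CC2)cc1` gives 5670 nM in this assay, and compound 2 `C#CCNC(=O)/C=C/c1c(/C=C/c2ccc(OC)cc2)cc(OC)cc1OC` gives 8280 nM; with a 2.7-fold lower number from compound 1 to compound 3 (0.44 log units; beyond the scatter) and a 4.0-fold lower number from compound 2 to compound 3 (0.60 log units; beyond the scatter) compound 3 stands apart from both. Compound 4 `COc1ccc(/C=C/c2cc(OC)cc(OC)c2/C=C/C(=O)NC(C)C)cc1` is not yet measured. It differs from compound 3 in one place: isopropyl in place of butyl on an amide-type nitrogen. The measured steps that bear on this are a 4.0-fold lower number from compound 2 to compound 3 (0.60 log units; beyond the scatter), a change of the saturated chain on the amide-type nitrogen, and a 2.7-fold lower number from compound 1 to compound 3 (0.44 log units; beyond the scatter), an exchange of the whole group on the carbonyl carbon; both moved the number down toward compound 3. For the measured compounds named here, no measured step shortens the butyl chain itself, so the direction is uncertain, and a modest rise at most is expected, within or just beyond the scatter. For compound 4 the expected value in this assay is 3200 nM, range 1300 nM to 8000 nM. The expected step is a 1.5-fold higher number from compound 3 to compound 4 (0.19 log units; within the scatter).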

Compound 4, half-maximal inhibitory concentration: 4020 nM
Beside the measured number, compound 4's estimate is 1.3-fold (0.10 log units) below it, and the stated range covers the measured number.
By their numbers in this assay, from the lowest: compounds 3, 4, 1 and 2 (each within the scatter of the next, the first and the last beyond it).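

At the amide-type nitrogen in this assay, isopropyl and butyl cannot be told apart, with a 1.9-fold higher number from compound 3 to compound 4 (0.29 log units; within the scatter), so the low number of compound 3 does not mark butyl as a distinct optimum over this shorter group. Isopropyl keeps a modest gap to propargyl, with a 2.1-fold lower number from compound 2 to compound 4 (0.31 log units; beyond the scatter), but against the whole 4-methylpiperazin-1-yl group on the carbonyl carbon it shows a 1.4-fold lower number from compound 1 to compound 4 (0.15 log units; within the scatter), so only butyl stands beyond the scatter from that group. No supporting data bear on these differences.

On these data alone, it remains open whether a longer chain such as hexyl, or a chain ending in a carboxylic acid or a primary amine, would lie beyond the scatter from butyl. Also open, as far as these compounds go, is how a dimethylamino group on the carbonyl carbon would compare with 4-methylpiperazin-1-yl.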